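Sugar Stereochemistry Swap in a Diterpene Glycoside Series

This account rests on a few compounds, and the source may have more. Where it says the series, first, only, none or still open, it means among the compounds named here.

Three compounds were tested in a functional assay on SK-MEL-2 cells (Homo sapiens) for cytotoxicity, read by sulforhodamine B assay; on this read-out higher numbers stand for an effect only at larger amounts of compound and lower numbers for an effect already at smaller amounts. Compound 1 `C=C[C@](C)(O)CC[C@H]1C(C)=CC[C@H]2C(C)(C)CCC[C@]12C` gives 4.4 ug/mL, and compound 3 `C=C[C@@](C)(CC[C@H]1C(C)=CC[C@H]2C(C)(C)CCC[C@]12C)O[C@@H]1O[C@@H](C)[C@@H](OC(C)=O)[C@H](O)[C@H]1O` gives 3.5 ug/mL; these two values lie within the usual scatter of each other. Compound 2 `C=C[C@@](C)(CC[C@@H]1[C@@]2(C)CCCC(C)(C)[C@@H]2CC[C@@]1(C)O)O[C@@H]1O[C@H](C)[C@H](O)[C@H](O)[C@H]1O` gives only a limit of the assay, > 5 ug/mL, so no number is known for it (the limit of > 5 ug/mL in this assay, at which 1 of the 3 values shown sits). The unmeasured compound 4 `C=C[C@@](C)(CC[C@@H]1[C@@]2(C)CCCC(C)(C)[C@@H]2CC[C@@]1(C)O)O[C@H]1O[C@H](C)[C@H](O)[C@@H](O)[C@@H]1O` keeps every atom and bond of compound 2; (the two compounds have the same atoms and bonds and differ only in configuration as drawn: 3 of 10 stereo elements differ; a stereocentre at a saturated ring carbon is drawn S in compound 2 and R in compound 4; a stereocentre at a saturated ring carbon is drawn S in compound 2 and R in compound 4; a stereocentre at a saturated ring carbon is drawn R in compound 2 and S in compound 4). Among the compounds with values here, no step between measured compounds shows how such a change in drawn configuration acts here. The step that the limit leaves unreadable from compound 2 to compound 4 is expected to be small, within the scatter. Compound 4 is therefore expected to give about 6 ug/mL, with a range from 3 ug/mL to 12 ug/mL, and may again fall at the limit.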

Compound 4, concentration for half-maximal effect: > 5 ug/mL
Compound 4 was reported as a limit (the forecaster's own chance of this, stated with the estimate: 65%); the middle value lies beyond the limit too.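

Within the data shown here, compound 2 and compound 4 both give only a limit and not a number, so no step between them can be read. The compounds shown leave open whether changing the drawn configuration alters cytotoxicity at all.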